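Ester size and expected inhibition at the adenosine receptor

A few compounds are considered here, and "the series" means these few. Any claim that something is new, unique, unknown or untested is made for them only; others in the source may bear on it.

In an assay on membranes from HeLa cells for displacement of a labelled ligand from adenosine receptor A3 (Homo sapiens), read by scintillation counting, with a stated time of 180 min, tested at 1 uM (a higher number here means more inhibition at the concentration tested (going by the name of the read-out), a lower number less inhibition), the measured compounds give:
Compound 1 `CC1=C(C(N)=O)C(c2ccsc2)NC(=O)N1` gives 1%
Compound 2 `CCC(CC)OC(=O)C1=C(C)NC(=O)NC1c1ccsc1` gives 6%
Compound 3 `CCC(C)OC(=O)C1=C(C)NC(=O)NC1c1ccsc1` gives 7%

Compound 3 lies within the scatter of both others: a number 6 percentage points higher from compound 1 to compound 3 (within the scatter) and a number 1 percentage points higher from compound 2 to compound 3 (within the scatter). Compound 4 `CC1=C(C(=O)OC2CCCCC2)C(c2ccsc2)NC(=O)N1` differs from compound 3 by cyclohexyl in place of sec-butyl on an oxygen next to a carbonyl group. Going by the values given here, only one measured step changes the size of the group on that oxygen, a number 1 percentage points higher from compound 2 to compound 3 (within the scatter), and the two steps that put an alkoxy group there in place of amino, a number 5 percentage points higher from compound 1 to compound 2 (within the scatter) and a number 6 percentage points higher from compound 1 to compound 3 (within the scatter), also stay within the scatter. A larger cyclohexyl group has not been tested, but nothing seen so far suggests a step beyond the scatter. Compound 4 is therefore expected to show a number 1 percentage points higher from compound 3 to compound 4 (within the scatter), giving an estimated 8% in this assay, ranging from 0% to 20%.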

Compound 4, a percentage reported as inhibition, at one concentration (the size of the read-out at that concentration, not a potency): 1%
Estimate against measurement, compound 4: 7 percentage points above; low and high end bracket the measured number.
By their numbers in this assay, from the lowest: compounds 1, 4, 2 and 3 (each within the scatter of the next).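

Cyclohexyl brings a ring onto the oxygen next to a carbonyl group, yet in this assay this leaves the read-out within the scatter of both open-chain esters (a number 6 percentage points lower from compound 3 to compound 4 (within the scatter); a number 5 percentage points lower from compound 2 to compound 4 (within the scatter)). The ester with this ring also stays within the scatter of the amide (no change at the digits printed from compound 1 to compound 4 (within the scatter)), so sec-butyl, pentan-3-yl, cyclohexyl and amino cannot be told apart here. As far as these compounds go, whether a phenyl ring, a longer chain or a carboxylic acid at this place would give a step beyond the scatter remains open. No supporting evidence bears on this result.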